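Phenyl for Methyl on the Core of Compound 1

This account rests on a few compounds, and the source may have more. Where it says the series, first, only, none or still open, it means among the compounds named here.

Measured compounds:
compound 1, `C/N=C(\S)NCCCCn1nc(C)ccc1=O`, > 100 mg/kg in a functional assay on the whole organism (stomach) with Rattus norvegicus as the target; a lower number here means that less compound is needed, a higher number that more compound is needed for the effect
compound 2, `C/N=C(/NC#N)NCCCCn1nc(-c2ccccc2)cc(C)c1=O`, 60.8 mg/kg
compound 3, `C/N=C(/NC#N)NCCCCn1nc(-c2ccc(Cl)cc2)ccc1=O`, 100 mg/kg

The value given for compound 1 is a limit of this assay and not a number. Among the three results it is the only entry of its kind: the limit of > 100 mg/kg in this assay, at which 1 of the 3 values shown sits. Compound 2 gives 60.8 mg/kg and compound 3 gives 100 mg/kg, both numbers rather than limits, and both carry a cyano group on the amidine nitrogen where compound 1 carries sulfur.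

The unmeasured compound 4, `C/N=C(\S)NCCCCn1nc(-c2ccccc2)ccc1=O`, keeps the sulfur of compound 1 and differs from it in one place: phenyl in place of methyl on an aromatic carbon. Going by the values given here, no measured pair differs by this change alone, so only an expectation can be stated. Since compound 1 stands at a limit, any step from it is poorly defined; the step is estimated as a number no higher from compound 1 to compound 4 (the limit leaves the size open), that is, no clear change beyond the usual scatter, with some chance of a modest gain. Compound 4 is therefore expected to give 100 mg/kg, with a range from 40 mg/kg to 250 mg/kg.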

Compound 4, dose for half-maximal effect: 28.9 mg/kg
Compound 4: middle estimate off by 3.5-fold (0.54 log units), on the high side; measured number outside the range, below it.
By their numbers in this assay, from the lowest: compound 4; then compounds 2 and 3 (each within the scatter of the next).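

In this assay, phenyl in place of methyl on this aromatic carbon gives an at least 3.4-fold lower number from compound 1 to compound 4 (0.53 log units; beyond the scatter), the first single change at this position among the compounds shown. The value for compound 1 is a limit and not a number, which leaves the full size of the step open: the limit of > 100 mg/kg in this assay, at which 1 of the 4 values shown sits. Compound 2 and compound 3 carry an aromatic ring at this carbon only alongside a cyano group in place of sulfur, so they could not show the effect of this change alone.

The compounds shown leave open whether a cyclohexyl group or a longer alkyl chain at this carbon would give a similar step, or whether a methoxy group on the phenyl would shift the number further. They also leave open whether the same exchange gives a similar step when a cyano group replaces the sulfur.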